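Bromine on the phenyl ring of a reductase inhibitor

This account rests on a few compounds, and the source may have more. Where it says the series, first, only, none or still open, it means among the compounds named here.

Of the compounds shown here, two with a shared core have been measured in an assay on isolated protein for inhibition of 3-hydroxy-3-methylglutaryl-coenzyme A reductase (Homo sapiens); on this read-out lower numbers stand for stronger inhibition and higher numbers for weaker inhibition. Compound 1 `CC(C)c1nc(-c2ccc(F)cc2)c(-c2cc(Cl)cc(Cl)c2)n1/C=C/[C@@H](O)C[C@@H](O)CC(=O)O` gives 7.66 nM in this assay. Going by the values given here, compound 2 `CC(C)c1cc(-c2ccc(F)cc2)c(-c2ccccc2)n1/C=C/[C@@H](O)C[C@@H](O)CC(=O)O` gives 7.6 nM in this assay, a number that sits within the usual scatter of the one for compound 1, so the two cannot be told apart on these data. Compound 3 `CC(C)c1cc(-c2ccc(F)cc2)c(-c2cccc(Br)c2)n1/C=C/[C@@H](O)C[C@@H](O)CC(=O)O` has not been measured. It differs from compound 2 by bromo in place of hydrogen on an aromatic carbon, the phenyl becoming a 3-bromophenyl. Among the compounds with values here, no pair among the measured compounds shows a single change of this kind, so nothing here points to a shift in either direction. Since compound 1 and compound 2 give indistinguishable numbers despite their different substitution of the same ring, compound 3 is expected to give a number close to that of compound 2, with a step of a 1.1-fold lower number from compound 2 to compound 3 (0.04 log units; within the scatter) that stays within the scatter. The value of compound 3 in this assay is estimated at 7 nM, with a range from 3 nM to 18 nM.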

Compound 3, half-maximal inhibitory concentration: 7.16 nM
Compound 3: the middle estimate sits 1.0-fold (0.01 log units) below what was measured; the range from low to high includes it.
By their numbers in this assay, from the lowest: compounds 3, 2 and 1 (each within the scatter of the next).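

In this assay, going by these compounds alone, bromo in place of hydrogen on an aromatic carbon, which turns the phenyl into a 3-bromophenyl, gives a 1.1-fold lower number from compound 2 to compound 3 (0.03 log units; within the scatter), the first single change that can be read in this set. This carbon of the ring therefore carries a bromine, one heavy atom larger than hydrogen, with no shift that can be told from repeat measurement, so compound 3 and compound 2 cannot be separated on these numbers. Nothing at hand offers an explanation for this result.

Going by these compounds, whether an amine, a carboxylic acid or a longer chain at the same carbon would also leave the number undisturbed remains open. On these data alone, it is also open whether bromo would give a similar result at another carbon of this ring or on the core of compound 1.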